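Notes on the chain-carbon substituent: estimating compound 4

A few compounds are considered here, and "the series" means these few. Any claim that something is new, unique, unknown or untested is made for them only; others in the source may bear on it.

Measured so far in an in vitro functional assay on cells for agonist activity at Bombesin receptor subtype-3 (Homo sapiens), read by luminescence and calcium flux; on this read-out higher numbers stand for an effect only at larger amounts of compound and lower numbers for an effect already at smaller amounts:
- compound 1 `Cc1cccc(Cc2cnc(CCc3ccc(-c4ccccc4C(=O)O)cc3)[nH]2)c1` — compound 1 gives 4310 nM
- compound 2 `CC(C)(C)Cc1cnc(CCc2ccc(-c3ccccc3C(=O)O)cc2)[nH]1` — compound 2 gives 106 nM
- compound 3 `O=C(O)c1ccccc1-c1ccc(CCc2ncc(Cc3cccc(F)c3F)[nH]2)cc1` — compound 3 gives 87 nM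

Compound 3 has the lowest number of the three; its nearest neighbour is compound 2, at a gap within the scatter, so no order between them can be claimed. Compound 1 stands far away from both, and the two steps of a 41-fold lower number from compound 1 to compound 2 (1.61 log units; beyond the scatter) and a 50-fold lower number from compound 1 to compound 3 (1.69 log units; beyond the scatter) show how much the group on the saturated chain carbon bound to an aromatic carbon matters.

The unmeasured compound 4 `Cc1ccccc1Cc1cnc(CCc2ccc(-c3ccccc3C(=O)O)cc2)[nH]1` differs from compound 3 in this change: 2-methylphenyl in place of 2,3-difluorophenyl on a saturated chain carbon bound to an aromatic carbon

Of the measured steps, the one most directly comparable is the change from 3-methylphenyl in compound 1 to 2,3-difluorophenyl in compound 3, which was large; compound 4 brings back a methylphenyl group, though with the methyl at a different position as the name says, so the 3-methylphenyl result cannot be carried over directly. The expectation is for compound 4 to sit somewhere between compound 1 and compound 3, with a step of an 8.0-fold higher number from compound 3 to compound 4 (0.91 log units; beyond the scatter) upward in this assay and wide uncertainty. Compound 4 is therefore estimated at 700 nM, with a range from 120 nM to 4000 nM.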

Compound 4, half-maximal effective concentration: 127 nM
Compound 4: middle estimate off by 5.5-fold (0.74 log units), on the high side, within the range that was stated.
By their numbers in this assay, from the lowest: compounds 3, 2 and 4 (each within the scatter of the next); then compound 1.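

In this assay the change at the saturated chain carbon bound to an aromatic carbon gives a 1.5-fold higher number from compound 3 to compound 4 (0.16 log units; within the scatter) and a 1.2-fold higher number from compound 2 to compound 4 (0.08 log units; within the scatter), so 2-methylphenyl cannot be told apart from 2,3-difluorophenyl or tert-butyl at this place. Among the compounds shown here, the new point is that a methylphenyl group does not by itself go with the high number of compound 1: the swap of 3-methylphenyl for 2-methylphenyl gives a 34-fold lower number from compound 1 to compound 4 (1.53 log units; beyond the scatter), a large step for a change that leaves the count of heavy atoms and the group's name the same apart from the position number, and among the four compounds 3-methylphenyl is now the only group that stands apart from the rest. Nothing available here accounts for the gap between the two methylphenyl groups.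

As far as these compounds go, whether compound 1 reflects something peculiar to 3-methylphenyl or applies to other groups carrying that substitution, such as 3-fluorophenyl or 3-methoxyphenyl, remains open. Also open, from the compounds shown here alone, is how unsubstituted phenyl, 4-methylphenyl or a ring-bearing amine such as pyridyl would behave at this place, and whether the close agreement of tert-butyl, 2,3-difluorophenyl and 2-methylphenyl would hold for a longer chain.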